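Methoxy analogue in the cytotoxicity series: expectation

A few compounds are considered here, and "the series" means these few. Any claim that something is new, unique, unknown or untested is made for them only; others in the source may bear on it.

Measured so far in a functional assay on L1210 cells (Mus musculus) for cytotoxicity, read by MTT assay; on this read-out lower numbers stand for stronger inhibition and higher numbers for weaker inhibition:
- compound 1 `O=C(N/N=C/c1ccc(F)cc1)c1cn(C2CC2)c2cc(N3CCNCC3)c(F)cc2c1=O`: 25000 nM
- compound 2 `O=C(N/N=C/c1ccccc1)c1cn(C2CC2)c2cc(N3CCNCC3)c(F)cc2c1=O`: 25000 nM

Compound 2 stands level with compound 1, as no change at the digits printed from compound 1 to compound 2 (within the scatter) shows; that step was hydrogen in place of fluoro on an aromatic carbon. Compound 3 `COc1ccc(/C=N/NC(=O)c2cn(C3CC3)c3cc(N4CCNCC4)c(F)cc3c2=O)cc1` is not yet tested. Its change from compound 2 is methoxy in place of hydrogen on an aromatic carbon. Going by the values given here, the single measured step bears on it only loosely: it also swapped a group on an aromatic carbon and gave no change at the digits printed from compound 1 to compound 2 (within the scatter). On that footing no step beyond the scatter is expected in this assay, estimated as no change at the digits printed from compound 2 to compound 3 (within the scatter). Compound 3 is therefore expected near 25000 nM, within 10000 nM to 60000 nM.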

Compound 3, half-maximal inhibitory concentration: 25000 nM
For compound 3 middle estimate and measured number coincide at the digits printed, within the range that was stated.
By their numbers in this assay, from the lowest: compounds 1, 2 and 3 (each within the scatter of the next).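

In this assay, the phenyl to 4-methoxyphenyl change, on an aromatic carbon para to a large group, gives a flat result (no change at the digits printed from compound 2 to compound 3 (within the scatter)), and the comparison with the fluoro analogue reads the same (no change at the digits printed from compound 1 to compound 3 (within the scatter)). Previously only a swap of hydrogen and fluoro was on record at this carbon; a group of 2 heavy atoms, one of them oxygen, now leaves hydrogen, fluoro and methoxy indistinguishable here. No available measurement accounts for this result.

From the compounds shown here alone, whether an amine, a carboxylic acid or a longer alkoxy chain at this carbon would shift the number remains open. So does the response to changes elsewhere on the shared core.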